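The compounds below may be only part of what the source reports. "The series", "measured", "known", "first", "only" and "open" are said of these compounds alone.

Measured so far in an assay on RBL-1 cells for inhibition of Polyunsaturated fatty acid 5-lipoxygenase (Rattus norvegicus); a higher number here means a weaker inhibitor, a lower number a stronger inhibitor:
Compound 1 `CC(=O)N(O)C(C)c1ccc(OCc2ccccc2)cc1` gives 280 nM.
Compound 2 `CC(c1ccc(OCc2ccccc2)cc1)N(O)C=O` gives 940 nM.

Going by the values given here, compound 2 stands highest of the two numbers; the only measured step, a 3.4-fold higher number from compound 1 to compound 2 (0.53 log units; beyond the scatter), concerns the carbonyl carbon and not the aryl ether side of the core. Compound 3 `CCCCOc1ccc(C(C)N(O)C=O)cc1` differs from compound 2 by propyl in place of phenyl on a saturated chain carbon bound to an oxygen on an aromatic ring. Among the compounds with values here, no measured step touches this part of the structure, so there is no basis for a directed expectation and the estimate stays near compound 2 with a wide range. In this assay compound 3 is expected at 1200 nM, between 400 nM and 3600 nM. The expected step is a 1.3-fold higher number from compound 2 to compound 3 (0.11 log units; within the scatter), within the scatter.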

Compound 3, half-maximal inhibitory concentration: 1900 nM
Estimate against measurement, compound 3: 1.6-fold (0.20 log units) below, within the range that was stated.
By their numbers in this assay, from the lowest: compound 1; then compound 2; then compound 3.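

The group on the saturated chain carbon bound to an oxygen on an aromatic ring does register in this assay: propyl in place of phenyl gives a 2.0-fold higher number from compound 2 to compound 3 (0.31 log units; beyond the scatter) and so costs modestly. An aromatic ring at this place is therefore not required for a measurable value, though phenyl reads better than propyl in this pair. Nothing available explains the step.

Going by these compounds, a longer chain, an amine or a carboxylic acid at this place remains open. So does whether the same change on compound 1 gives a step of like size.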